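Trimming the Amide Tail on a Shared Core

The source may hold more compounds than are shown below. What is called first, only, known or untested is meant among the compounds shown, and "the series" means these compounds.

Measured so far:
compound 1 `COc1ccc(-c2c(C)nn3c(NCCNC(=O)C(C)C)cc(C)nc23)cc1OC`: > 100000 nM
compound 2 `CC(=O)NCCNc1cc(Cl)nn2c(-c3cccc(S(=O)(=O)NC(C)C)c3)c(C)nc12`: > 100000 nM

Of the compounds shown here, two have been tested in an assay on isolated protein for inhibition of phosphatidylinositol 4-kinase type 2-alpha (Homo sapiens), read by ADP-Glo, with a stated time of 60 min; a lower number here means a stronger inhibitor, a higher number a weaker inhibitor. Compound 1 gives only a limit of the assay there, > 100000 nM, and no number. Compound 2 likewise gives only a limit in this assay, > 100000 nM. Both readings thus sit at the same place, as noted in the limit of > 100000 nM in this assay, at which 2 of the 2 values shown sit, and nothing more can be said of where compound 1 stands than that it lies at that limit. Among the compounds with values here, no step between the two measured compounds is defined, as they differ in more than one place.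

Compound 3 `COc1ccc(-c2c(C)nn3c(NCCNC(C)=O)cc(C)nc23)cc1OC` has not yet been measured. It differs from compound 1 by methyl in place of isopropyl on a carbonyl carbon. Since compound 1 itself returns only a limit, the step from compound 1 to compound 3 is expected to be a step that the limit leaves unreadable from compound 1 to compound 3, with no direction resolvable beyond the scatter. Compound 3 is therefore expected to read about 150000 nM in this assay, within a range of 30000 nM to 500000 nM, most likely reported again as a limit.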

Compound 3, half-maximal inhibitory concentration: > 100000 nM
Compound 3: a limit, no number; the forecaster's own chance of this, stated with the estimate: 85%; the middle value lies beyond the limit too.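

No step can be read between compound 1 and compound 3, since both give only a limit in this assay, and methyl in place of isopropyl on a carbonyl carbon therefore has no readable size: the limit of > 100000 nM in this assay, at which 3 of the 3 values shown sit.

The compounds shown leave open what any change to the amide tail does to a measurable inhibition.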